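The source may hold more compounds than are shown below. What is called first, only, known or untested is meant among the compounds shown, and "the series" means these compounds.

Compounds measured in a functional assay on HeLa cells (Homo sapiens) for antiproliferative activity, read by MTT assay, with a stated time of 72 h; on this read-out lower numbers stand for stronger inhibition and higher numbers for weaker inhibition:

Compound 1 `CC(=O)OCC(CCn1cc(C#Cc2ccc(Br)cc2)c(=O)n(C(=O)c2ccccc2)c1=O)COC(C)=O`: 47200 nM
Compound 2 `CCCCCc1ccc(C#Cc2cn(CCC(COC(C)=O)COC(C)=O)c(=O)n(C(=O)c3ccccc3)c2=O)cc1`: 79100 nM
Compound 3 `CCCCCCCCC#Cc1cn(CCC(COC(C)=O)COC(C)=O)c(=O)n(C(=O)c2ccccc2)c1=O`: 32400 nM

Among these three, compound 3 carries the lowest number. Its nearest neighbour is compound 1, with a 1.5-fold lower number from compound 1 to compound 3 (0.16 log units; within the scatter) lying within the scatter; the gap to compound 2, a 2.4-fold lower number from compound 2 to compound 3 (0.39 log units; beyond the scatter), is the only one of the set that reaches beyond it. The remaining pair, a 1.7-fold higher number from compound 1 to compound 2 (0.22 log units; within the scatter), also stays within the scatter, so the three numbers sit close together.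

Compound 4 `CC(=O)OCC(CCn1cc(C#CC(C)(C)C)c(=O)n(C(=O)c2ccccc2)c1=O)COC(C)=O` differs from compound 3 in one place: tert-butyl in place of octyl on a triple-bonded carbon. The measured steps that touch the same position are the two that brought an octyl group onto the triple-bonded carbon, a 1.5-fold lower number from compound 1 to compound 3 (0.16 log units; within the scatter) and a 2.4-fold lower number from compound 2 to compound 3 (0.39 log units; beyond the scatter); both were small, and both compared the octyl chain with an aryl group rather than with a shorter chain. Among the measured compounds shown here, no measured pair shows what shortening the chain itself does. On this evidence the expected step in this assay is small and without a firm direction, so compound 4 is estimated at 42000 nM, with a range from 15000 nM to 115000 nM, which corresponds to an expected step of a 1.3-fold higher number from compound 3 to compound 4 (0.11 log units; within the scatter).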

Compound 4, half-maximal inhibitory concentration: 71500 nM
For compound 4 the middle estimate is 1.7-fold (0.23 log units) below the measured one, within the range that was stated.
By their numbers in this assay, from the lowest: compounds 3, 1, 4 and 2 (each within the scatter of the next, the first and the last beyond it).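

Within this assay, the octyl and tert-butyl compounds give the first comparison of two alkyl groups on the triple-bonded carbon, and this change is not neutral (a step of a 2.2-fold higher number from compound 3 to compound 4 (0.34 log units; beyond the scatter)), though it is modest. The tert-butyl group, in contrast, cannot be told apart from either aryl group at this position (steps of a 1.1-fold lower number from compound 2 to compound 4 (0.04 log units; within the scatter) and a 1.5-fold higher number from compound 1 to compound 4 (0.18 log units; within the scatter)), so an alkyl group on this carbon does not by itself set a compound apart from those carrying an aryl group, and the four numbers still span only a narrow band. Nothing available here accounts for the step from octyl to tert-butyl.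

The compounds shown change chain length and branching together, so a straight butyl chain or a branched chain as long as octyl would be needed to tell which of the two matters. Also open, from the compounds shown here alone, is how this position responds to a group other than a hydrocarbon or bromoaryl one, such as a chain ending in an amine or a carboxylic acid.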